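Difluorophenyl isomers on the piperidine carbon: compound 2 to 3

This account rests on a few compounds, and the source may have more. Where it says the series, first, only, none or still open, it means among the compounds named here.

Measured so far:
compound 1 `Fc1ccccc1C1CCN(Cc2ccn3c(CC4CC4)nnc3c2C(F)(F)F)CC1`: 353%
compound 2 `Fc1cccc(F)c1C1CCN(Cc2ccn3c(CC4CC4)nnc3c2C(F)(F)F)CC1`: 330%

Compound 2 stands lowest of the two numbers in an assay on CHO cells for positive allosteric modulation of metabotropic glutamate receptor 2 (Homo sapiens), read by scintillation counting, with a stated time of 30 min; on this read-out higher numbers stand for larger maximal responses and lower numbers for smaller maximal responses; compound 1 lies a number 23 percentage points lower from compound 1 to compound 2 (beyond the scatter). Compound 3 `Fc1ccc(C2CCN(Cc3ccn4c(CC5CC5)nnc4c3C(F)(F)F)CC2)c(F)c1` carries the change (2,4-difluorophenyl in place of 2,6-difluorophenyl on a saturated ring carbon). Within the data shown here, no measured step bears directly on this exchange; the only step known, from compound 1 to compound 2, adds a fluoro and was modest. Moving a fluorine rather than adding one is therefore expected to give a step of at most similar size, direction unclear. Compound 3 is estimated at 335% (range 285% to 385%), a step of a number 5 percentage points higher from compound 2 to compound 3 (within the scatter) that is expected to stay near the scatter.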

Compound 3, largest response reached (Emax), in percent of the reference or control that the assay uses: 255%
Compound 3: middle estimate off by 80 percentage points, on the high side; measured number outside the range, below it.
By their numbers in this assay, from the lowest: compound 3; then compound 2; then compound 1.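

In this assay, the same atoms joined differently give a number 75 percentage points lower from compound 2 to compound 3 (beyond the scatter), so 2,4-difluorophenyl and 2,6-difluorophenyl are not interchangeable on this saturated ring carbon. Placement of the added fluoro therefore counts as well as its presence, with the 2,4-difluorophenyl pattern giving a number 98 percentage points lower from compound 1 to compound 3 (beyond the scatter). No available data account for the difference between the two isomers. Open, from the compounds shown here alone, is how a chloro or methoxy group on this aromatic ring would compare with fluoro. Also open, going by these compounds, is where an unsubstituted phenyl group would fall.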